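The source may report more compounds than this note shows. Statements on the series, on what has been measured and on what is new or still open speak of the compounds shown alone.

Compound 1 `CSc1nc(NCCCCNc2ccnc3cc(Cl)ccc23)c(C#N)c(-c2cccc([N+](=O)[O-])c2)n1`: 1100 nM
Compound 2 `CSc1nc(NCCCCNc2ccnc3cc(Cl)ccc23)c(C#N)c(-c2ccc([N+](=O)[O-])cc2)n1`: 890 nM
Compound 3 `COc1ccc(-c2nc(SC)nc(NCCCCNc3ccnc4cc(Cl)ccc34)c2C#N)cc1`: 3400 nM

In an ADME assay on HeLa cells (Homo sapiens) for inhibition, read by cell counting (a higher number here means a weaker inhibitor, a lower number a stronger inhibitor), compound 3 stands at 3400 nM, the highest number of the three, which makes it the weakest inhibitor of this small set. Compound 4 `COc1cc(-c2nc(SC)nc(NCCCCNc3ccnc4cc(Cl)ccc34)c2C#N)cc(OC)c1OC` keeps the shared core and changes one group: 3,4,5-trimethoxyphenyl in place of 4-methoxyphenyl on an aromatic carbon. In words, 3,4,5-trimethoxyphenyl replaces 4-methoxyphenyl on an aromatic carbon.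

For the measured compounds named here, no measured step adds methoxy groups to a ring that already carries one, so the evidence is only indirect. The nearest comparison is a 3.8-fold higher number from compound 2 to compound 3 (0.58 log units; beyond the scatter), where methoxy replaces nitro. The change in a 3.1-fold higher number from compound 1 to compound 3 (0.49 log units; beyond the scatter) is of similar size, while a 1.2-fold lower number from compound 1 to compound 2 (0.09 log units; within the scatter) shows that moving the nitro group made no clear difference. Across these three compounds, changing this group gave modest steps or none, and none of them shows which way extra methoxy groups would push the number.

In this assay the expected step is a 1.1-fold lower number from compound 3 to compound 4 (0.05 log units; within the scatter), so no change beyond the scatter is expected, although a modest move either way is possible. Compound 4 is estimated at 3000 nM, with an expected range of 1200 nM to 8000 nM.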

Compound 4, half-maximal inhibitory concentration: 3400 nM
Compound 4: the middle estimate sits 1.1-fold (0.05 log units) below what was measured; measured number inside the range.
By their numbers in this assay, from the lowest: compounds 2 and 1 (each within the scatter of the next); then compounds 3 and 4 (each within the scatter of the next).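

In this assay, the extra methoxy groups of 3,4,5-trimethoxyphenyl leave the number where it was, with no change at the digits printed from compound 3 to compound 4 (within the scatter) as the step, so at this position the larger ring group reads the same as 4-methoxyphenyl. The gap to the nitro compounds also remains, with a 3.8-fold higher number from compound 2 to compound 4 (0.58 log units; beyond the scatter) and a 3.1-fold higher number from compound 1 to compound 4 (0.49 log units; beyond the scatter) closely matching the steps already seen for compound 3, so among these four compounds both methoxy-bearing rings give higher numbers than both nitrophenyl rings. Nothing available here explains why the added groups leave the number unchanged.

On these data alone, whether a single extra methoxy group would behave in the same way remains open. So does the effect of a phenyl ring carrying an amine or a carboxylic acid at this position.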